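A few compounds are considered here, and "the series" means these few. Any claim that something is new, unique, unknown or untested is made for them only; others in the source may bear on it.

Compound 3 `N#Cc1cnc(NCc2cnccc2C(F)(F)F)cc1N[C@H]1CC[C@@H](C(N)=O)CC1` gives the lowest number among the three compounds measured in an assay on isolated protein for inhibition of protein kinase C theta type (Homo sapiens), read by TR-FRET, with a stated time of 2 h; on this read-out higher numbers stand for weaker inhibition and lower numbers for stronger inhibition; in this assay compound 3 gives 7 nM. Compound 2 `CO[C@H]1CC[C@@H](Nc2cc(NCc3cnccc3C(F)(F)F)ncc2C#N)CC1` gives 58 nM, and compound 1 `N#Cc1cnc(NCc2cnccc2C(F)(F)F)cc1NC[C@H]1C[C@@H](O)C1` gives 300 nM. The step of a 43-fold lower number from compound 1 to compound 3 (1.63 log units; beyond the scatter) and the step of a 5.2-fold lower number from compound 1 to compound 2 (0.71 log units; beyond the scatter) both lower the number, and the step of an 8.3-fold lower number from compound 2 to compound 3 (0.92 log units; beyond the scatter) shows that exchanging the substituent on the saturated ring matters on its own.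

Compound 4 `CC1(C)C[C@H](Nc2cc(NCc3cnccc3C(F)(F)F)ncc2C#N)CC[C@@H]1O` carries a change in the same part of the molecule: 4-hydroxy-3,3-dimethylcyclohexyl in place of 4-carbamoylcyclohexyl on a nitrogen on an aromatic ring. The measured step that bears most directly on it is an 8.3-fold lower number from compound 2 to compound 3 (0.92 log units; beyond the scatter), in which replacing a carbamoyl group with a methoxy group moved the number in the unfavourable direction. Going by the values given here, compound 4 carries a hydroxy group rather than a carbamoyl group, together with two methyl groups on the ring, and no measured pair shows that combination. Compound 4 is therefore expected to give a higher number than compound 3, an estimated step of a 5.0-fold higher number from compound 3 to compound 4 (0.70 log units; beyond the scatter), so that compound 4 is estimated at 35 nM with a range from 10 nM to 120 nM.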

Compound 4, half-maximal inhibitory concentration: 7 nM
The estimate for compound 4 lay 5.0-fold (0.70 log units) above the measured number, and the stated range ends above it.
By their numbers in this assay, from the lowest: compounds 3 and 4 (each within the scatter of the next); then compound 2; then compound 1.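

In this assay, going by these compounds alone, the exchange of 4-carbamoylcyclohexyl for 4-hydroxy-3,3-dimethylcyclohexyl on a nitrogen on an aromatic ring gives no change at the digits printed from compound 3 to compound 4 (within the scatter) and so shows that the carbamoyl group is not the only group at this place compatible with a number in this range. The new group also separates from the other two groups, with an 8.3-fold lower number from compound 2 to compound 4 (0.92 log units; beyond the scatter) and a 43-fold lower number from compound 1 to compound 4 (1.63 log units; beyond the scatter) on the same read-out. Nothing available accounts for the match between compound 3 and compound 4.

The compounds shown do not separate the contribution of the hydroxy group from that of the two methyl groups, since none carries a plain 4-hydroxycyclohexyl group on this nitrogen. They also leave open how an amine or a carboxylic acid in place of the carbamoyl group would read in this assay.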